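The source may report more compounds than this note shows. Statements on the series, on what has been measured and on what is new or still open speak of the compounds shown alone.

Compound 1 `O=C(Nc1cccc(S(=O)(=O)C2CCCC2)c1)c1cccnc1N1CCC(F)(F)CC1` has been measured in an ADME assay on microsomes from liver (Homo sapiens) for metabolic stability, read by LC-MS, with a stated time of 40 min, tested at 0.5 uM; on this read-out higher numbers stand for fast clearance and lower numbers for slow clearance. In this assay compound 1 gives > 399 mL.min-1.g-1, which is a limit of the assay and not a number. Compound 2 `CC(C)(O)CNc1ccc(C(=O)Nc2cccc(S(=O)(=O)C3CCCC3)n2)c(N2CCC3(CC2)CC3)c1`, a larger molecule with a different substitution pattern, gives > 399 mL.min-1.g-1, which is also a limit. Compound 1 therefore stands at the limit of > 399 mL.min-1.g-1 in this assay, at which 2 of the 2 values shown sit.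

The next compound, compound 3 `O=C(Nc1cccc(S(=O)(=O)C2CCCC2)c1)c1cccnc1N1CCCCC1`, keeps the core of compound 1 but carries piperidin-1-yl in place of 4,4-difluoropiperidin-1-yl on an aromatic carbon. Within the data shown here, no measured pair of compounds differs in just one place, so the data give no direct guide to the size of this change. No shift beyond the usual scatter is expected, and clearance is expected to remain fast. The expected change is a step that the limit leaves unreadable from compound 1 to compound 3. In this assay the estimate for compound 3 is 400 mL.min-1.g-1, with an expected range of 200 mL.min-1.g-1 to 800 mL.min-1.g-1.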

Compound 3, intrinsic clearance in microsomes: > 399 mL.min-1.g-1
Compound 3 ended at the assay's limit; the forecaster's own chance of this, stated with the estimate: 65%; the middle value lies beyond the limit too.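

In this assay compound 1 and compound 3 both sit at a limit and not at a number, so no size can be read for the step between them: the limit of > 399 mL.min-1.g-1 in this assay, at which 3 of the 3 values shown sit. From the compounds shown here alone, how far past that limit each compound lies, and whether piperidin-1-yl and 4,4-difluoropiperidin-1-yl differ at all in clearance, stays open.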